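Cytotoxicity notes on a shared-core series

A few compounds are considered here, and "the series" means these few. Any claim that something is new, unique, unknown or untested is made for them only; others in the source may bear on it.

Compound 1 `CCCOc1nc(N)nc2c1ncn2/C=C1/CC1(CO)CO`, compound 2 `CCOc1nc(N)nc2c1ncn2/C=C1/CC1(CO)CO` and compound 3 `Nc1nc(SC2CCCC2)c2ncn(/C=C3/CC3(CO)CO)c2n1` share one core and differ only at a single aromatic carbon. In an ADME assay on HFF cells (Homo sapiens) for cytotoxicity, with a stated time of 8 days (on this read-out lower numbers stand for higher toxicity in this test and higher numbers for lower toxicity in this test), compound 1 returns only the limit > 300000 nM, not a number. In this assay compound 2 likewise stops at the limit > 300000 nM. In this assay compound 3 also sits at the limit > 300000 nM, so its standing among the three cannot be read: the limit of > 300000 nM in this assay, at which 3 of the 3 values shown sit. Compound 4 `CC(C)Nc1nc(N)nc2c1ncn2/C=C1/CC1(CO)CO` follows from compound 3 by isopropylamino in place of cyclopentylsulfanyl on an aromatic carbon. The steps a step that the two limits leave unreadable from compound 1 to compound 3 and a step that the two limits leave unreadable from compound 2 to compound 3 concern the same carbon, yet both are unreadable, so in this assay no step beyond the scatter can be foreseen. Compound 4 is expected to remain at the limit, estimated at 400000 nM with a range of 150000 nM to 1500000 nM, an expected step that the limit leaves unreadable from compound 3 to compound 4.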

Compound 4, half-maximal cytotoxic concentration: > 300000 nM
Compound 4: a limit, no number (the forecaster's own chance of this, stated with the estimate: 80%); the middle value is on the limit's open side.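

In this assay no new step can be read between compound 4 and compound 1, compound 2 or compound 3, each a limit and not a number: the limit of > 300000 nM in this assay, at which 4 of the 4 values shown sit.

The compounds shown leave open whether any group on this aromatic carbon would give a readable number.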